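The compounds below may be only part of what the source reports. "The series", "measured", "known", "first", "only" and "open" are said of these compounds alone.

Measured so far in this assay:
compound 1, `CC(C)N(Cc1cccc(OCCCCCC(=O)O)c1)C(=O)c1ccc(-c2ccc3c(c2)OCCO3)cc1` — > 21900 nM
compound 2, `CCOC(=O)CCCCCOc1cccc(CN(C(=O)c2ccc(-c3cccc(NC(C)=O)c3)cc2)C(C)C)c1` — > 26000 nM
compound 3, `CCOC(=O)CCCCCOc1cccc(CN(C(=O)c2ccc(-c3cccc(OC(C)C)c3)cc2)C(C)C)c1` — > 26000 nM

Every value in an ADME assay on HEK293 cells (Homo sapiens) for cytotoxicity, read by CellTiter-Glo and resazurin assay, with a stated time of 72 h (on this read-out lower numbers stand for an effect already at smaller amounts and higher numbers for an effect only at larger amounts of compound), is a limit of the assay, not a number. Compound 3 gives > 26000 nM, which is a limit. Compound 2 likewise gives > 26000 nM, a limit. Compound 1 gives > 21900 nM, a limit as well. Two of the three values sit at the limit of > 26000 nM in this assay, at which 2 of the 3 values shown sit, and one sits at the limit of > 21900 nM in this assay, at which 1 of the 3 values shown sits. Within the data shown here, the only step between measured neighbours, a step that the two limits leave unreadable from compound 2 to compound 3, cannot be read, since both ends are limits.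

Compound 4, `CCOC(=O)CCCCCOc1cccc(CN(C(=O)c2ccc(-c3ccc4c(c3)OCCO4)cc2)C(C)C)c1`, differs from compound 3 by 2,3-dihydro-1,4-benzodioxin-6-yl in place of 3-isopropoxyphenyl on an aromatic carbon. Among the measured compounds shown here, no measured step covers this change. For the measured compounds named here, what can be said is that compound 1 carries the same 2,3-dihydro-1,4-benzodioxin-6-yl group and stands at a limit, so none of the measured compounds, with either group, shows an effect within the tested range. Compound 4 is therefore expected to stand at a limit too, and the step that the limit leaves unreadable from compound 3 to compound 4 is expected to be unreadable rather than a real move. The estimate for compound 4 is 40000 nM, with a range from 20000 nM to 120000 nM, and most likely only a limit will be reported.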

Compound 4, half-maximal effective concentration: > 24400 nM
Compound 4 gave a limit, no number; the forecaster's own chance of this, stated with the estimate: 85%; the middle value does not contradict the limit.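

All four values in this assay are limits of the assay, and the steps from compound 1, compound 2 and compound 3 to compound 4 cannot be read. The compounds shown leave open at what concentration, if any, each of them would have an effect on these cells, and whether the changes among them alter that concentration.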